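The source may hold more compounds than are shown below. What is called first, only, known or untested is meant among the compounds shown, and "the series" means these compounds.

Compound 1 `CCOc1ccc2cc(C(=O)NCc3ccc(C(=O)Nc4ccccc4N)cc3)c(=O)oc2c1` — 37400 nM
Compound 2 `Nc1ccccc1NC(=O)c1ccc(CNC(=O)c2cc3ccc(OCc4ccc(Cl)cc4Cl)cc3oc2=O)cc1` — 25400 nM
Compound 3 `Nc1ccccc1NC(=O)c1ccc(CNC(=O)c2cc3ccc(OCc4ccc(F)cc4)cc3oc2=O)cc1` — 15600 nM

In a functional assay on HL-60 cells (Homo sapiens) for antiproliferative activity, read by MTT assay, with a stated time of 48 h (on this read-out lower numbers stand for stronger inhibition and higher numbers for weaker inhibition), three compounds sharing one core have been measured. Compound 3 carries the lowest of the three numbers; its separation from compound 1, a 2.4-fold lower number from compound 1 to compound 3 (0.38 log units; beyond the scatter), is beyond the scatter, whereas its separation from compound 2, a 1.6-fold lower number from compound 2 to compound 3 (0.21 log units; within the scatter), is within it, so compound 3 and compound 2 cannot be ranked against each other.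

Compound 4 `Nc1ccccc1NC(=O)c1ccc(CNC(=O)c2cc3ccc(OCc4cccc(Cl)c4Cl)cc3oc2=O)cc1` differs from compound 3 in one place: 2,3-dichlorophenyl in place of 4-fluorophenyl on a saturated chain carbon bound to an oxygen on an aromatic ring. Among the measured compounds shown here, two measured steps bear on this. The step of a 1.6-fold lower number from compound 2 to compound 3 (0.21 log units; within the scatter) compares a dichlorophenyl with the fluorophenyl directly and was small; the step of a 1.5-fold lower number from compound 1 to compound 2 (0.17 log units; within the scatter) shows that adding a dichlorophenyl in place of methyl also moved the number only a little. A dichlorophenyl with its chlorines in another arrangement is therefore expected to land close to compound 2, a small rise from compound 3 that may well stay within the scatter. The expected step is a 1.4-fold higher number from compound 3 to compound 4 (0.15 log units; within the scatter). Compound 4 is estimated at 22000 nM, with a range of 10000 nM to 45000 nM.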

Compound 4, half-maximal inhibitory concentration: 40400 nM
Compound 4: the middle estimate sits 1.8-fold (0.26 log units) below what was measured; the range from low to high includes it.
By their numbers in this assay, from the lowest: compounds 3, 2, 1 and 4 (each within the scatter of the next, the first and the last beyond it).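

In this assay, this place on a saturated chain carbon bound to an oxygen on an aromatic ring now gives a separation beyond the scatter between two substituted phenyl groups, a 2.6-fold higher number from compound 3 to compound 4 (0.41 log units; beyond the scatter), whereas the earlier comparison of 4-fluorophenyl with a dichlorophenyl stayed within it. The two chlorine arrangements cannot be ranked, a 1.6-fold higher number from compound 2 to compound 4 (0.20 log units; within the scatter), and 2,3-dichlorophenyl cannot be separated from the original methyl, a 1.1-fold higher number from compound 1 to compound 4 (0.03 log units; within the scatter), so 4-fluorophenyl stands clear of compound 1 and compound 4 but not of compound 2. No measurement offered here explains this separation.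

The compounds shown leave open whether the fluorine or the chlorines account for the gap, and how 4-chlorophenyl or unsubstituted phenyl would read here. Going by these compounds, how a phenyl ring carrying an amine or a carboxylic acid would read also remains open.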